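The source may hold more compounds than are shown below. What is called first, only, known or untested is meant among the compounds shown, and "the series" means these compounds.

Series notes. Compound 1 `O=S(=O)(Nc1nnc(SCc2ccc(Cl)cc2)s1)c1ccccc1` gives 89% in a toxicity assay on HaCaT cells (Homo sapiens) for cytotoxicity, tested at 125 uM; a higher number here means a weaker effect of the compound at the concentration tested, a lower number a stronger effect. For the measured compounds named here, compound 2 `Cc1ccc(S(=O)(=O)Nc2nnc(SCc3ccc(Cl)cc3)s2)cc1` gives 85% in this assay, and the single measured step in the set, a number 4 percentage points lower from compound 1 to compound 2 (within the scatter), lies within the scatter. Compound 3 `COc1ccc(S(=O)(=O)Nc2nnc(SCc3ccccc3)s2)cc1` gives 79% in this assay; this is the lowest of the three numbers, with compound 2 nearest and compound 1 furthest, but both gaps are within the scatter, so the three numbers do not separate. Compound 4 `COc1ccc(S(=O)(=O)Nc2nnc(SCc3ccc(Cl)cc3)s2)cc1` differs from compound 3 in one place: chloro in place of hydrogen on an aromatic carbon. Going by the values given here, no measured step bears directly on this change. Among the compounds with values here, the only step in hand, a number 4 percentage points lower from compound 1 to compound 2 (within the scatter), is a different change on the same kind of ring and stayed within the scatter. Compound 1, which carries the chloro group but also differs from compound 3 in another place, sits within the scatter of compound 3 on the numbers alone. Nothing in the set therefore points to a step beyond the scatter in this assay, in either direction. The expected step is a number 3 percentage points higher from compound 3 to compound 4 (within the scatter). Compound 4 is estimated at 82% in this assay, with a range from 70% to 93%.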

Compound 4, a percentage reported as activity, at one concentration (the size of the read-out at that concentration, not a potency): 90%
Estimate against measurement, compound 4: 8 percentage points below, within the range that was stated.
By their numbers in this assay, from the lowest: compounds 3, 2, 1 and 4 (each within the scatter of the next, the first and the last beyond it).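

Para to a large group on the benzyl ring, the change from benzyl to 4-chlorobenzyl gives a number 11 percentage points higher from compound 3 to compound 4 (beyond the scatter) in this assay, the only step in the set that lies beyond the scatter, and it points to a weaker effect at the concentration tested. Among the compounds that carry the 4-chlorobenzyl group, methoxy in place of methyl gives a number 5 percentage points higher from compound 2 to compound 4 (within the scatter) and methoxy in place of hydrogen gives a number 1 percentage points higher from compound 1 to compound 4 (within the scatter), so these changes on the other aromatic ring do not separate the compounds, and only the chloro change moves the number beyond the scatter. The compounds in hand offer no measurement that accounts for the chloro step.

As far as these compounds go, the chloro step rests on a single pair with methoxy on the other ring, so it remains open whether it would hold with hydrogen or methyl there. From the compounds shown here alone, it is also open whether another group at the same place, such as bromo, an amine or a carboxylic acid, would move the number in this assay as chloro does.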